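Trifluoromethyl in place of methoxy: notes on the series

The source may hold more compounds than are shown below. What is called first, only, known or untested is meant among the compounds shown, and "the series" means these compounds.

Of the compounds shown here, three have been measured in a functional assay on SK-OV-3 cells (Homo sapiens) for cytotoxicity, read by spectrophotometry, with a stated time of 72 h; a lower number here means a stronger inhibitor, a higher number a weaker inhibitor. Compound 1 `COc1ccc(-n2c(-c3cc(OC)c(OC)c(OC)c3)cccc2=O)cc1OCc1ccccc1` gives 25500 nM, compound 2 `COc1ccc(-n2c(-c3cc(OC)c(OC)c(OC)c3)cccc2=O)cc1` gives 1540 nM and compound 3 `COc1cc(-c2cccc(=O)n2-c2ccncc2)cc(OC)c1OC` gives 3020 nM. Compound 2 and compound 3 lie within the scatter of each other, and compound 2 stands well clear of compound 1.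

The next step leads to the unmeasured compound 4 `COc1cc(-c2cccc(=O)n2-c2ccc(C(F)(F)F)cc2)cc(OC)c1OC`. The change from compound 2 is trifluoromethyl in place of methoxy on an aromatic carbon, para to a large group (trifluoromethyl in place of methoxy on an aromatic carbon).

Among the measured compounds shown here, two measured steps bear on it. The closer one also alters the 4-methoxyphenyl group: pyridin-4-yl in its place on an aromatic nitrogen gives a 2.0-fold higher number from compound 2 to compound 3 (0.29 log units; within the scatter). The other, hydrogen in place of benzyloxy on an aromatic carbon, gives a 17-fold lower number from compound 1 to compound 2 (1.22 log units; beyond the scatter). That large step involves a different substituent, so it sets no size for this change, though it shows that the same aromatic ring can carry a large effect.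

With the closer step as the guide, this assay is expected to show only a small shift, within the scatter. The expected step is a 1.6-fold higher number from compound 2 to compound 4 (0.21 log units; within the scatter). For compound 4 the estimated value is 2500 nM, with an expected range of 800 nM to 8000 nM.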

Compound 4, half-maximal inhibitory concentration: 1920 nM
The estimate for compound 4 lay 1.3-fold (0.11 log units) above the measured number; low and high end bracket the measured number.
By their numbers in this assay, from the lowest: compounds 2, 4 and 3 (each within the scatter of the next); then compound 1.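

In this assay, trifluoromethyl in place of methoxy on an aromatic carbon, para to a large group, gives a 1.2-fold higher number from compound 2 to compound 4 (0.10 log units; within the scatter). Among the compounds shown here, this is the first exchange that keeps the six-membered aromatic ring of carbon only and changes just the group at this position, and it shows that the oxygen of methoxy can leave and fluorine can enter without a shift beyond the scatter, so at this position the level of compound 2 does not depend on methoxy. No measured property of either group is available to account for this flat step, so the result stands as an observation on these two groups alone.

The compounds shown leave open whether this position stays as flat in this assay with an amine, a carboxylic acid or a longer chain such as butoxy in place of methoxy, since only two groups have been compared here. They also leave open whether the same exchange behaves alike on other cell lines, or when the trimethoxyphenyl part of the shared core is changed.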